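From iodo to ethynyl on the aromatic ring

The compounds below may be only part of what the source reports. "The series", "measured", "known", "first", "only" and "open" are said of these compounds alone.

In a functional assay on SK-OV-3 cells (Homo sapiens) for antiproliferative activity, read by MTT assay, with a stated time of 72 h (on this read-out higher numbers stand for weaker inhibition and lower numbers for stronger inhibition), compound 1 `O=C(CCc1cccc2c1B(O)OC2)Nc1ccccc1` gives 200 nM, compound 2 `O=C(CCc1cccc2c1B(O)OC2)Nc1ccc(Br)cc1` gives 9200 nM, and compound 3 `O=C(CCc1cccc2c1B(O)OC2)Nc1ccc(I)cc1` gives 51000 nM. Compound 3 has the highest number of the three and so the weakest inhibition.

Compound 4 `C#Cc1ccc(NC(=O)CCc2cccc3c2B(O)OC3)cc1` differs from it by ethynyl in place of iodo on an aromatic carbon, para to a large group.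

For the measured compounds named here, three measured steps bear on this change. Bromo in place of hydrogen gave a large step, a 46-fold higher number from compound 1 to compound 2 (1.66 log units; beyond the scatter), and iodo in place of hydrogen gave another, a 260-fold higher number from compound 1 to compound 3 (2.41 log units; beyond the scatter). Iodo in place of bromo gave a modest one, a 5.5-fold higher number from compound 2 to compound 3 (0.74 log units; beyond the scatter). Going by the values given here, no ethynyl compound has been measured, so the basis is thin. A modest step to a lower number in this assay is expected, similar in size to a 5.5-fold higher number from compound 2 to compound 3 (0.74 log units; beyond the scatter) but opposite in direction, with no full return to the value of compound 1 at 200 nM. The estimated change is a 4.3-fold lower number from compound 3 to compound 4 (0.63 log units; beyond the scatter). For compound 4 the estimated value is 12000 nM, within an expected range of 2500 nM to 45000 nM.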

Compound 4, half-maximal inhibitory concentration: 6300 nM
Compound 4: middle estimate off by 1.9-fold (0.28 log units), on the high side, and the stated range covers the measured number.
By their numbers in this assay, from the lowest: compound 1; then compounds 4 and 2 (each within the scatter of the next); then compound 3.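

At the aromatic carbon para to a large group, the cost is not confined to halogens: in this assay, ethynyl in place of hydrogen gives a 32-fold higher number from compound 1 to compound 4 (1.50 log units; beyond the scatter). Ethynyl in place of iodo recovers only part of that cost, with an 8.1-fold lower number from compound 3 to compound 4 (0.91 log units; beyond the scatter), while ethynyl in place of bromo gives a 1.5-fold lower number from compound 2 to compound 4 (0.16 log units; within the scatter), so compound 2 and compound 4 cannot be told apart here. All three substituents shown at this position give a higher number than hydrogen, and none of the four compounds goes against this.

No measurement at hand accounts for these differences. As far as these compounds go, whether an amine, a carboxylic acid or a methoxy group at this position comes close to compound 1 at 200 nM remains open.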